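The source may hold more compounds than are shown below. What is called first, only, known or untested is meant among the compounds shown, and "the series" means these compounds.

Compound 1, `O=S(=O)(c1ccc(Br)cc1)c1nc2ccccc2nc1Nc1ccccc1`, is the starting point. In a functional assay on HCT-116 cells (Homo sapiens) for cytotoxicity, read by MTT assay, with a stated time of 72 h (on this read-out higher numbers stand for weaker inhibition and lower numbers for stronger inhibition), compound 1 gives 1110 nM. Compound 2, `COc1ccc(Nc2nc3ccccc3nc2S(=O)(=O)c2ccc(Br)cc2)cc1`, differs from it in one place: methoxy in place of hydrogen on an aromatic carbon. In this assay compound 2 gives 3400 nM. That change brought a 3.1-fold higher number from compound 1 to compound 2 (0.49 log units; beyond the scatter).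

Compound 3, `COc1cc(Nc2nc3ccccc3nc2S(=O)(=O)c2ccc(Br)cc2)cc(OC)c1`, carries a different core from compound 1, and the difference is 3,5-dimethoxyphenyl in place of phenyl on a nitrogen on an aromatic ring. For compound 3 this assay reports only a limit, > 50000 nM, which is the limit of > 50000 nM in this assay, at which 1 of the 3 values shown sits. The step of an at least 45-fold higher number from compound 1 to compound 3 (1.65 log units; beyond the scatter) and the step of an at least 14-fold higher number from compound 2 to compound 3 (1.16 log units; beyond the scatter) are both large.

Compound 4, `COc1cc(Nc2nc3ccccc3nc2S(=O)(=O)c2ccc(Br)cc2)cc(OC)c1OC`, has not been measured. It differs from compound 3 by methoxy in place of hydrogen on an aromatic carbon. Among the compounds with values here, this is the same kind of change as the one from compound 1 to compound 2, but the surroundings differ: in compound 4 the entering methoxy sits ortho to two methoxy groups (2 heavy atoms each) as well as para to a large group, whereas in compound 2 it sits only para to a large group.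

Since compound 3 already stands at a limit, > 50000 nM, compound 4 is expected to give a step that the limit leaves unreadable from compound 3 to compound 4 in this assay, and its value is estimated at 100000 nM, within 30000 nM to 400000 nM.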

Compound 4, half-maximal inhibitory concentration: 13000 nM
For compound 4 the middle estimate is 7.7-fold (0.89 log units) above the measured one, outside the stated range (below it).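

In this assay, the methoxy entering on an aromatic carbon brings an at least 3.8-fold lower number from compound 3 to compound 4 (0.58 log units; beyond the scatter), so in these two pairs the change does not carry a fixed effect from one core to another: the same change on two cores in this assay, a 3.1-fold higher number (0.49 log units; beyond the scatter) from compound 1 to compound 2 and an at least 3.8-fold lower number (0.58 log units; beyond the scatter) from compound 3 to compound 4, at least 11-fold (1.07 log units) apart, beyond the scatter of two such steps

The value of compound 3, > 50000 nM, is a limit and not a number.

The two steps show that the same change can move the read-out in opposite directions in this series, and that in compound 4, where the methoxy sits ortho to two methoxy groups, it goes with a lower number; they do not show why this happens or how large the step from compound 3 truly is.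

The compounds shown leave open whether another group at that place, such as an amine, a hydroxyl or a longer chain, would behave like methoxy on either core. They also leave open whether a chlorine or a carboxylic acid in place of the bromine would alter these steps.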